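The compounds below may be only part of what the source reports. "The series", "measured", "known", "first", "only" and "open" are said of these compounds alone.

Of the compounds shown here, three sharing one core have been measured in an assay on liver for inhibition of sterol O-acyltransferase 1 (Rattus norvegicus), using microsomes; on this read-out lower numbers stand for stronger inhibition and higher numbers for weaker inhibition. Compound 1 `CCCCCCCCCCCCn1nnc(C(C(=O)Nc2ccc(F)cc2F)c2ccccc2)n1` gives 31 nM; compound 2 `CCCCCCCCCCCCn1nnc(C(C(=O)Nc2c(C)nn(C)c2C)c2ccccc2)n1` gives 13 nM; compound 3 `CCCCCCCCCCCCn1nnc(C(C(=O)Nc2ccc3c(C)cc(C)nc3n2)c2ccccc2)n1` gives 1540 nM. Compound 2 thus shows the lowest number of the three: the step of a 2.4-fold lower number from compound 1 to compound 2 (0.38 log units; beyond the scatter) is modest, while the step of a 120-fold higher number from compound 2 to compound 3 (2.07 log units; beyond the scatter) is large, and so is the step of a 50-fold higher number from compound 1 to compound 3 (1.70 log units; beyond the scatter).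

Compound 4 `CCCCCCCCCCCCn1nnc(C(C(=O)NC(C)(C)C)c2ccccc2)n1` differs from compound 2 in one place: tert-butyl in place of 1,3,5-trimethyl-1H-pyrazol-4-yl on an amide-type nitrogen. The group that leaves carries one five-membered aromatic ring with two hetero atoms and two hydrogen-bond acceptors; the group that enters has no ring and no hydrogen-bond acceptors.

The measured steps all exchange one aromatic group on the amide-type nitrogen for another. Between compound 1 and compound 2 the exchange of one ring for another moved the number only modestly, whereas enlarging the group to two fused rings in compound 3 raised it sharply. Among the compounds with values here, no measured step removes the ring altogether, so the step to compound 4 reaches outside the tested changes; a rise of moderate size in this assay is expected, with wide uncertainty, as a 4.6-fold higher number from compound 2 to compound 4 (0.66 log units; beyond the scatter). Compound 4 is therefore estimated at 60 nM, with a range from 15 nM to 300 nM.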

Compound 4, half-maximal inhibitory concentration: 3350 nM
The estimate for compound 4 lay 56-fold (1.75 log units) below the measured number; measured number above the stated range.
By their numbers in this assay, from the lowest: compound 2; then compound 1; then compound 3; then compound 4.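

Removing the ring from the group on the amide-type nitrogen proves far more costly in this assay than exchanging one single ring for another, with a 260-fold higher number from compound 2 to compound 4 (2.41 log units; beyond the scatter) and a 110-fold higher number from compound 1 to compound 4 (2.03 log units; beyond the scatter). A ring alone does not secure a low number, however: the fused pair of rings in compound 3 leaves only a modest gap to tert-butyl, at a 2.2-fold higher number from compound 3 to compound 4 (0.34 log units; beyond the scatter), so the smallest and the largest groups shown both give high numbers, while the two single-ring groups of intermediate size give low numbers. No measurement shown here accounts for this behaviour at the position.

The compounds shown do not separate the presence of a ring from that of an aromatic ring, since tert-butyl differs from 1,3,5-trimethyl-1H-pyrazol-4-yl in both ring and atom count. A cyclohexyl group on the same nitrogen would address that question, and an unsubstituted phenyl group would show how much the fluorines of compound 1 and the methyl groups of compound 2 contribute.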